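The compounds below may be only part of what the source reports. "The series", "measured", "known", "first", "only" and "open" are said of these compounds alone.

Three compounds share one core and differ in a single aromatic ring group. In an ADME assay on a cell-free system (plasma, Homo sapiens) for protein binding (a higher number here means a larger unbound share of the compound, a lower number a smaller unbound share), compound 1 `Cc1cc(C)c(-c2ncc[nH]2)cc1NC(=O)c1ccc(OCc2ccccn2)cc1` gives 0.067 and compound 2 `Cc1ncc(-c2cc(NC(=O)c3ccc(OCc4ccccn4)cc3)c(C)cc2C)[nH]1` gives 0.095, and a 1.4-fold higher number from compound 1 to compound 2 (0.15 log units; within the scatter) does not separate them. Compound 3 `Cc1cc(C)c(-c2c[nH]nc2C)cc1NC(=O)c1ccc(OCc2ccccn2)cc1` stands lowest of the three at 0.021.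

The next change leads to compound 4 `Cc1cc(C)c(-c2ccc(N)nn2)cc1NC(=O)c1ccc(OCc2ccccn2)cc1`: 6-aminopyridazin-3-yl in place of 3-methyl-1H-pyrazol-4-yl on an aromatic carbon. It puts 6-aminopyridazin-3-yl in place of 3-methyl-1H-pyrazol-4-yl on an aromatic carbon. Within the data shown here, no measured compound carries a six-membered aromatic ring at this place, so the evidence is indirect. The two relevant steps both involve the departing 3-methyl-1H-pyrazol-4-yl group: a 3.2-fold lower number from compound 1 to compound 3 (0.50 log units; beyond the scatter) and a 4.5-fold lower number from compound 2 to compound 3 (0.66 log units; beyond the scatter). Both are modest, and both end at the lowest number in the set. From the compounds shown here alone, removing that group is therefore expected to give a modest rise in this assay, though the incoming ring is untested.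

The expected change is a 2.4-fold higher number from compound 3 to compound 4 (0.38 log units; beyond the scatter). For compound 4 the estimate is 0.05, with an expected range from 0.02 to 0.11.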

Compound 4, unbound fraction: 0.064
Compound 4: middle estimate off by 1.3-fold (0.11 log units), on the low side; measured number inside the range.
By their numbers in this assay, from the lowest: compound 3; then compounds 4, 1 and 2 (each within the scatter of the next).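

In this assay, 6-aminopyridazin-3-yl brings a six-membered aromatic ring to this place and gives a 3.0-fold higher number from compound 3 to compound 4 (0.48 log units; beyond the scatter) as a modest step, so the low number of compound 3 does not carry over to this ring. The other two steps, a 1.5-fold lower number from compound 2 to compound 4 (0.17 log units; within the scatter) and a 1.0-fold lower number from compound 1 to compound 4 (0.02 log units; within the scatter), stay within the scatter, which leaves compounds 1, 2 and 4 unseparated despite their different ring sizes, with compound 3 alone apart from all three. No measured information accounts for the position of compound 3 or for the rise with the new ring.

The compounds shown leave open what the amine of 6-aminopyridazin-3-yl contributes apart from its ring. Also open, from the compounds shown here alone, is how a carboxylic acid or a longer chain on that ring would read in this assay on the shared core.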